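Removing the nitro group: compound 4 against compound 2

The source may report more compounds than this note shows. Statements on the series, on what has been measured and on what is new or still open speak of the compounds shown alone.

Of the compounds shown here, three have been measured in a physicochemical assay for lipophilicity, in phosphate buffer, measured as octanol-water partition, with a stated time of 24 h; on this read-out higher numbers stand for higher lipophilicity and lower numbers for lower lipophilicity. Compound 1 `Cc1ccc(Oc2ccc(/C=N/NC(=O)CSc3nc4ccccc4s3)cc2)cc1` gives 5.7. For the measured compounds named here, compound 3 `O=C(CSc1nc2ccccc2s1)N/N=C/c1ccc(Oc2ccc3ccccc3c2)cc1` gives 5.9; the one change between these two, naphthalen-2-yl in place of 4-methylphenyl on an oxygen on an aromatic ring, produced a number 0.20 log units higher from compound 1 to compound 3 (within the scatter). Compound 2 `O=[N+]([O-])c1ccc(Oc2ccc(/C=N/Nc3nc4ccccc4s3)cc2)cc1` gives 5.1, the lowest of the three numbers; compound 1 stands nearest to it and compound 3 furthest, both beyond the scatter. No single-change step is shown between compound 2 and either of the others, so only their values can be compared.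

Compound 4 `C(=N/Nc1nc2ccccc2s1)\c1ccc(Oc2ccccc2)cc1` is obtained from compound 2 by one change: hydrogen in place of nitro on an aromatic carbon. Going by the values given here, neither measured step concerns this change; the only step on record, the step in this assay from compound 1 to compound 3, touches a different part of the molecule. The expectation therefore rests on the structural change alone. Because compound 2 gives 5.1 and nothing larger than the scatter is expected, the step of a number 0.20 log units higher from compound 2 to compound 4 (within the scatter) is estimated to stay within the usual scatter. Compound 4 is expected to give 5.3, with a range from 4.8 to 5.8.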

Compound 4, partition coefficient: 5.2
Estimate against measurement, compound 4: 0.10 log units above; the measured number falls inside the stated range.
By their numbers in this assay, from the lowest: compounds 2 and 4 (each within the scatter of the next); then compounds 1 and 3 (each within the scatter of the next).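

In this assay, for the compounds shown here, hydrogen in place of nitro on an aromatic carbon, para to a large group, gave a number 0.10 log units higher from compound 2 to compound 4 (within the scatter); this is the first step on record at this position, while the one earlier step, a number 0.20 log units higher from compound 1 to compound 3 (within the scatter), concerned naphthalen-2-yl in place of 4-methylphenyl. Within this single pair, the loss of nitro, with its 3 heavy atoms, 2 hydrogen-bond acceptors and 1 double bond outside aromatic rings, left the two numbers within the scatter of each other, so 4-nitrophenyl and phenyl cannot be told apart on this read-out. No measurement on hand offers an explanation for this result.

The compounds shown leave open whether another group at this position, such as an amine, a carboxylic acid or a longer alkoxy chain, would give a step beyond the scatter, as one pair says nothing about groups other than nitro and hydrogen. They also leave open whether hydrogen in place of nitro would give a similar step on the core of compound 1, which differs from the core of compound 2.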